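Swapping the amide nitrogen side chain in the series

The source may hold more compounds than are shown below. What is called first, only, known or untested is meant among the compounds shown, and "the series" means these compounds.

Measured so far in a functional assay on MCF7 cells (Homo sapiens), read by MTT assay, with a stated time of 48 h (on this read-out higher numbers stand for weaker inhibition and lower numbers for stronger inhibition), on three compounds
compound 1 `CCn1c(C(=O)NCCN(C)C)ccc1C(CC)(CC)c1ccc(OCC(=O)C(C)(C)C)c(C)c1` gives 520 nM
compound 2 `CCn1c(C(=O)NCCCN(C)C)ccc1C(CC)(CC)c1ccc(OCC(=O)C(C)(C)C)c(C)c1` gives 340 nM
compound 3 `CCn1c(C(=O)NCCCN(C)C)ccc1C(CC)(CC)c1ccc(OCC(O)C(C)(C)C)c(C)c1` gives 490 nM

Compound 2 does not stand apart from its two neighbours. Within the data shown here, the series shows a 1.5-fold lower number from compound 1 to compound 2 (0.18 log units; within the scatter) and a 1.4-fold higher number from compound 2 to compound 3 (0.16 log units; within the scatter) as its only measured steps, and neither separates compound 2 from the others.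

Compound 4 `CC[C@@H](C)[C@H](NC(=O)c1ccc(C(CC)(CC)c2ccc(OCC(=O)C(C)(C)C)c(C)c2)n1CC)C(=O)O` is the next case. It carries 1-carboxy-2-methylbutyl in place of 3-(dimethylamino)propyl on an amide-type nitrogen, counted as 1-carboxy-2-methylbutyl in place of 3-(dimethylamino)propyl on an amide-type nitrogen in full. Only a 1.5-fold lower number from compound 1 to compound 2 (0.18 log units; within the scatter) falls on this side chain, and that step merely adds (dimethylamino)methyl in place of dimethylamino. The other step, a 1.4-fold higher number from compound 2 to compound 3 (0.16 log units; within the scatter), lies at the far chain bound to an oxygen on an aromatic ring and says nothing about this place. From the compounds shown here alone, every measured compound keeps the dimethylamino end, so the exchange itself is untested and the small steps seen so far cannot simply be carried over.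

A small move toward a higher number is expected, with low confidence in its direction, as a 1.9-fold higher number from compound 2 to compound 4 (0.28 log units; within the scatter) in this assay by estimate. Compound 4 is expected near 650 nM with an estimated range of 130 nM to 3000 nM in this wide first guess.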

Compound 4, half-maximal inhibitory concentration: 160 nM
Compound 4: the middle estimate sits 4.1-fold (0.61 log units) above what was measured; measured number inside the range.
By their numbers in this assay, from the lowest: compound 4; then compounds 2, 3 and 1 (each within the scatter of the next).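

In this assay, among these compounds, the amide-type nitrogen now gives the first steps that lie beyond the scatter: 1-carboxy-2-methylbutyl gives a 2.1-fold lower number from compound 2 to compound 4 (0.33 log units; beyond the scatter) when it replaces 3-(dimethylamino)propyl and a 3.3-fold lower number from compound 1 to compound 4 (0.51 log units; beyond the scatter) when it replaces 2-(dimethylamino)ethyl. The earlier change at this place only lengthened a chain that kept its dimethylamino end, whereas compound 4 shows that this end can be exchanged for a chain with no nitrogen and a carboxylic acid without the number rising, and both steps are modest. The data offer no measurement that accounts for these steps.

Still open, from the compounds shown here alone, is whether the lower number belongs to the carboxylic acid itself or to the branched carbon chain and the two defined stereocentres that enter with it, a question that a methyl ester at the same place, or a plain carboxymethyl group on this nitrogen, would help to separate. Also open, going by these compounds, is how a primary amine or a longer unbranched chain ending in a carboxylic acid would read at this nitrogen, and whether the 1-hydroxy-2,2-dimethylpropyl group at the far chain behaves the same way alongside 1-carboxy-2-methylbutyl.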